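The source may hold more compounds than are shown below. What is called first, only, known or untested is meant among the compounds shown, and "the series" means these compounds.

Measured in an ADME assay on Vero cells (Chlorocebus sabaeus) for cytotoxicity, read by MTT assay, with a stated time of 72 h; a lower number here means a stronger inhibitor, a higher number a weaker inhibitor:

- Compound 1 `O=C(O)c1cn(C2CC2)c2nc(N3CCC(n4c(=O)[nH]c5cc(Cl)ccc54)CC3)c([N+](=O)[O-])cc2c1=O`: 55500 nM
- Compound 2 `O=C(O)c1cn(-c2ccc(F)cc2)c2nc(N3CCC(n4c(=O)[nH]c5cc(Cl)ccc54)CC3)c([N+](=O)[O-])cc2c1=O`: 53900 nM
- Compound 3 `CC(C)(C)n1cc(C(=O)O)c(=O)c2cc([N+](=O)[O-])c(N3CCC(N4CCCCC4)CC3)nc21`: > 136000 nM, which is a limit of the assay and not a number

Compound 3 therefore has no exact position on the scale, and its entry is the limit of > 136000 nM in this assay, at which 1 of the 3 values shown sits.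

Compound 4 `CC(C)(C)n1cc(C(=O)O)c(=O)c2cc([N+](=O)[O-])c(N3CCC(n4c(=O)[nH]c5cc(Cl)ccc54)CC3)nc21` has not yet been measured. It differs from compound 3 in one place: a group of 11 heavy atoms (7 carbon, 2 nitrogen, 1 oxygen, 1 chlorine; one five-membered aromatic ring with 2 hetero atoms, one six-membered aromatic ring of carbon only) in place of a group of 6 heavy atoms (5 carbon, 1 nitrogen; one six-membered non-aromatic ring with 1 hetero atom), on a saturated ring carbon.

Among the compounds with values here, no measured step shows this exchange directly, but compound 1 and compound 2 both carry the entering group. Within the data shown here, the one measured step between them is a 1.0-fold lower number from compound 1 to compound 2 (0.01 log units; within the scatter). It changes a different part of the molecule and leaves the entering group in place. Among the measured compounds shown here, this single step suggests that the value may depend little on the substituent that changes there, although it covers only two compounds.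

Compound 4 is thus expected to lie near compound 1 at 55500 nM and compound 2 at 53900 nM. That would mean a lower number in this assay than the limit reached by compound 3, so stronger inhibition of the cells.

The expected size of the change is an at least 2.4-fold lower number from compound 3 to compound 4 (0.39 log units; beyond the scatter).

For compound 4 the estimated value is 55000 nM, with an expected range from 28000 nM to 110000 nM.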

Compound 4, half-maximal inhibitory concentration: 57700 nM
Beside the measured number, compound 4's estimate is 1.0-fold (0.02 log units) below it; the range from low to high includes it.
By their numbers in this assay, from the lowest: compounds 2, 1 and 4 (each within the scatter of the next). At a limit, above all of these: compound 3.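

In this assay, within the data shown here, replacing the piperidin-1-yl group on the saturated ring carbon with the chlorine-bearing group, while the tert-butyl group and the rest of the core stay the same, gives an at least 2.3-fold lower number from compound 3 to compound 4 (0.37 log units; beyond the scatter), the first direct reading of this exchange. That size is only a minimum, since compound 3 stands at a limit of the assay and not at an exact number: the limit of > 136000 nM in this assay, at which 1 of the 4 values shown sits.

The group on the aromatic nitrogen can now be compared across three examples with the chlorine-bearing group held in place, and tert-butyl gives a 1.0-fold higher number from compound 1 to compound 4 (0.02 log units; within the scatter) and a 1.1-fold higher number from compound 2 to compound 4 (0.03 log units; within the scatter), so the flat result seen earlier for cyclopropyl and 4-fluorophenyl also covers this third group.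

The compounds shown leave open how a primary amine or a morpholine ring on the same saturated ring carbon would read, and whether removing the chlorine would change the value. They also leave open whether a longer chain, such as n-hexyl, on the aromatic nitrogen would stay as flat, or whether that flatness would hold with piperidin-1-yl on the ring.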